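This account rests on a few compounds, and the source may have more. Where it says the series, first, only, none or still open, it means among the compounds named here.

Working notes on the selenium-containing hydroxamic acids in an assay on isolated protein for inhibition of protein deacetylase HDAC6 (Homo sapiens), read by fluorescence, with stated times of 15 min and 30 min; a lower number here means a stronger inhibitor, a higher number a weaker inhibitor. For the measured compounds named here, compound 1 `O=C(CCCCCn1[se]c2ccccc2c1=O)NO` gives 181 nM and compound 2 `O=C(CCCCCCn1[se]c2ccccc2c1=O)NO` gives 19 nM; the step of a 9.5-fold lower number from compound 1 to compound 2 (0.98 log units; beyond the scatter) is the only one-place step measured so far. Compound 3 `O=C(CCCCCOc1ccc(-n2[se]c3ccccc3c2=O)cc1)NO`, whose chain runs to an oxygen on an aromatic ring, gives 508 nM in this assay, the highest of the three numbers; compound 1 lies nearer to it than compound 2.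

Compound 4 `O=C(CCCCCCOc1ccc(-n2[se]c3ccccc3c2=O)cc1)NO` differs from compound 3 by (hydroxycarbamoyl)methyl in place of hydroxycarbamoyl on a saturated chain carbon, five bonds along the chain from an oxygen on an aromatic ring. This is the same lengthening of the chain as in the measured step of a 9.5-fold lower number from compound 1 to compound 2 (0.98 log units; beyond the scatter), there made on the chain attached to the aromatic nitrogen rather than on the chain attached to the ring oxygen. Going by the values given here, that single precedent points to a lower number for compound 4 in this assay; with no measured step on the oxygen-linked chain itself, a step in the same direction but somewhat smaller is estimated, a 5.6-fold lower number from compound 3 to compound 4 (0.75 log units; beyond the scatter). Compound 4 is therefore expected at about 90 nM, with a range from 25 nM to 300 nM.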

Compound 4, half-maximal inhibitory concentration: 181 nM
For compound 4 the middle estimate is 2.0-fold (0.30 log units) below the measured one; the range from low to high includes it.
By their numbers in this assay, from the lowest: compound 2; then compounds 1 and 4 (each within the scatter of the next); then compound 3.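

The change from hydroxycarbamoyl to (hydroxycarbamoyl)methyl also lowers the number on the chain attached to the ring oxygen, giving a 2.8-fold lower number from compound 3 to compound 4 (0.45 log units; beyond the scatter) in this assay, so the direction of the step is the same on both cores shown. The step therefore does not depend on which of these two chains carries it, at least in sign, but its size cannot be carried from one core to the other. The two steps differ in size: the same change on two cores in this assay, a 9.5-fold lower number (0.98 log units; beyond the scatter) from compound 1 to compound 2 and a 2.8-fold lower number (0.45 log units; beyond the scatter) from compound 3 to compound 4, 3.4-fold (0.53 log units) apart, beyond the scatter of two such steps

What the compounds shown leave open is whether a longer chain would lower the number further on either core, or whether the two cores would then diverge further. From the compounds shown here alone, it is also open how a carboxylic acid in place of hydroxycarbamoyl would read on either core.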